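The compounds below may be only part of what the source reports. "The series", "measured", "known", "first", "only" and "open" are said of these compounds alone.

Measured so far:
- compound 1 `COC1=C(C)C(=O)/C(=C(O)/C=C/c2ccc(C)cc2)C(=O)C1(C)C`: 5.1 ug/mL
- compound 2 `COC1=C(C)C(=O)/C(=C(O)/C=C/c2cccc3ccccc23)C(=O)C1(C)C`: 4.1 ug/mL

In a functional assay on A-431 cells (Homo sapiens) for cytotoxicity (a higher number here means that more compound is needed for the effect, a lower number that less compound is needed), compound 1 gives 5.1 ug/mL, the highest of the two numbers on hand. Compound 2 is the nearest, and in this assay compound 2 gives 4.1 ug/mL; the two values lie within the scatter, so nothing can be said of an order between them.

The next compound, compound 3 `COC1=C(C)C(=O)/C(=C(O)/C=C/c2nccs2)C(=O)C1(C)C`, is not yet measured. It differs from compound 1 in one place: 1,3-thiazol-2-yl in place of 4-methylphenyl on a double-bonded chain carbon bound to a double-bonded chain carbon. Going by the values given here, no step between measured compounds touches a change of this kind, so there is no measured step to lean on.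

Without such a step, the expected step from compound 1 to compound 3 is a 1.2-fold higher number from compound 1 to compound 3 (0.07 log units; within the scatter), none beyond the scatter. For compound 3 in this assay the estimate is 6 ug/mL, with a range from 2.5 ug/mL to 15 ug/mL.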

Compound 3, concentration for half-maximal effect: 6 ug/mL
For compound 3 middle estimate and measured number coincide at the digits printed; the range from low to high includes it.
By their numbers in this assay, from the lowest: compounds 2, 1 and 3 (each within the scatter of the next).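

Going by these compounds alone, at the position on a double-bonded chain carbon bound to a double-bonded chain carbon, 1,3-thiazol-2-yl in place of 4-methylphenyl gives a 1.2-fold higher number from compound 1 to compound 3 (0.07 log units; within the scatter) in this assay as the first readable step. The six-membered aromatic ring of carbon only can thus give way to a five-membered aromatic ring with 2 hetero atoms, with 2 hydrogen-bond acceptors entering, and the number stays within the scatter. No measurement on hand offers an explanation for this flat step.

Open, on these data alone, is whether this position stays as flat with a group that is not an aromatic ring, such as a carboxylic acid, an amine or a longer chain of carbon atoms. Also open, as far as these compounds go, is whether any change elsewhere on the shared core moves the number beyond the scatter.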